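From Chlorophenyl to Ethyl on a Weakly Cytotoxic Core

This account rests on a few compounds, and the source may have more. Where it says the series, first, only, none or still open, it means among the compounds named here.

Two measured compounds share one core. Compound 1 `Clc1ccccc1-c1nnc2nnc(N3CCCC3)nn12` gives 29600 nM in a functional assay on MCF7 cells (Homo sapiens) for cytotoxicity, read by MTT assay, with a stated time of 72 h (a lower number here means a stronger inhibitor, a higher number a weaker inhibitor), the highest of the two numbers. Among the compounds with values here, compound 2 `Clc1ccc(-c2nnc3nnc(N4CCCC4)nn23)c(Cl)c1` gives 19600 nM in the same assay, and the only measured step, a 1.5-fold lower number from compound 1 to compound 2 (0.18 log units; within the scatter), stays within the scatter.

The unmeasured compound 3 `CCc1nnc2nnc(N3CCCC3)nn12` differs from compound 1 as follows: ethyl in place of 2-chlorophenyl on an aromatic carbon. Within the data shown here, no measured step touches this change; the one step on record alters a substituent on the phenyl ring rather than removing that ring, so it offers little guidance beyond showing that the numbers moved little.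

Without a bearing step, no move beyond the scatter is expected, and the estimate for compound 3 leans on compound 1's own value 29600 nM. Compound 3 is therefore estimated at 35000 nM, ranging from 9000 nM to 130000 nM. That expectation corresponds to a 1.2-fold higher number from compound 1 to compound 3 (0.07 log units; within the scatter).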

Compound 3, half-maximal inhibitory concentration: 47000 nM
Compound 3: middle estimate off by 1.3-fold (0.13 log units), on the low side; measured number inside the range.
By their numbers in this assay, from the lowest: compounds 2, 1 and 3 (each within the scatter of the next, the first and the last beyond it).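

In this assay, ethyl in place of 2-chlorophenyl, on an aromatic carbon between two ring nitrogen atoms, gives a 1.6-fold higher number from compound 1 to compound 3 (0.20 log units; within the scatter). The earlier step only added a chloro group to the phenyl ring, whereas this change removes the whole six-membered aromatic ring of carbon only from this position, and the values of the two compounds still lie within the scatter of each other. On this single pair, then, a much smaller group without a ring at this position leaves the number in the same weak range, and no evidence at hand offers an explanation for this outcome.

The compounds shown leave open whether any group at this position, such as an amine, a carboxylic acid or a longer chain, would move the number beyond the scatter. They also leave open whether a phenyl ring carrying methoxy there would do so.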